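A few compounds are considered here, and "the series" means these few. Any claim that something is new, unique, unknown or untested is made for them only; others in the source may bear on it.

Compound 1, with the structure `COc1nc(N)nc2c1c(-c1cc3ccccc3o1)cn2[C@@H]1O[C@H](CO)[C@@H](O)[C@H]1O`, is one of three related nucleoside analogues tested in a functional assay on CEM-DNR-bulk cells (Homo sapiens), read by MTT assay, with a stated time of 72 h; on this read-out lower numbers stand for stronger inhibition and higher numbers for weaker inhibition. In this assay compound 1 gives 16700 nM, the highest of the two numbers obtained. Compound 3, `COc1ncnc2c1c(-c1cc3ccccc3o1)cn2[C@@H]1O[C@H](CO)[C@@H](O)[C@H]1O`, gives 10800 nM; the step of a 1.5-fold lower number from compound 1 to compound 3 (0.19 log units; within the scatter) comes from hydrogen in place of amino on an aromatic carbon. Compound 2, `Nc1nc(N)c2c(-c3cc4ccccc4o3)cn([C@@H]3O[C@H](CO)[C@@H](O)[C@H]3O)c2n1`, reaches only a limit of the assay, > 20000 nM. The step of an at least 1.1-fold higher number from compound 1 to compound 2 (0.07 log units; that floor lies within the scatter) follows amino in place of methoxy on an aromatic carbon, and the limit of > 20000 nM in this assay, at which 1 of the 3 values shown sits, means its true size is not known.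

Compound 4, `COc1nc(N)nc2c1c(-c1ccco1)cn2[C@@H]1O[C@H](CO)[C@@H](O)[C@H]1O`, differs from compound 1 as follows: furan-2-yl in place of 1-benzofuran-2-yl on an aromatic carbon. For the measured compounds named here, neither measured step touches this part of the structure, so no measured step bears directly on the change. All three measured compounds sit at weak inhibition, and the change to compound 4 is expected to give a 1.2-fold higher number from compound 1 to compound 4 (0.08 log units; within the scatter), no step beyond the scatter. The estimate for compound 4 in this assay is 20000 nM, expected to lie between 9000 nM and 45000 nM.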

Compound 4, half-maximal inhibitory concentration: > 20000 nM
Compound 4: only a limit was reported; the forecaster's own chance of this, stated with the estimate: 50%; the middle value lies on the limit itself.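

This is the first change shown at the aromatic carbon that carries the 1-benzofuran-2-yl group, and replacing that group with furan-2-yl gives an at least 1.1-fold higher number from compound 1 to compound 4 (0.07 log units; that floor lies within the scatter). In this assay, as far as these compounds go, compound 4 gives > 20000 nM, which is a limit and not a number, so the true size of the step stays unknown. The smaller group therefore shows no sign of stronger inhibition at this position, and a second compound now sits at the same limit: the limit of > 20000 nM in this assay, at which 2 of the 4 values shown sit.

The compounds shown leave open whether any other group on this carbon, such as a phenyl ring, a thiophen-2-yl ring or a simple methyl, would shift the number beyond the scatter. They also leave open how far compound 4 truly lies from compound 1.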